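A few compounds are considered here, and "the series" means these few. Any claim that something is new, unique, unknown or untested is made for them only; others in the source may bear on it.

Working notes on the series. The shared core of compound 3 `COc1cc(OCc2cccc(Sc3ccccc3)c2)c2cc(-c3cn4nc(OC)sc4n3)oc2c1` carries a phenylsulfanyl group on the benzylic aryl ring; in an assay on a cell-free system (plasma) for antagonist activity at proteinase-activated receptor 4 (Homo sapiens), with a stated time of 5 min, in the presence of a further agent that is not named here (on this read-out higher numbers stand for weaker inhibition and lower numbers for stronger inhibition), compound 3 gives 410 nM. Compound 2 `COc1cc(OCc2cccc(COc3ccccc3)c2)c2cc(-c3cn4nc(OC)sc4n3)oc2c1` carries phenoxymethyl at the same place and in this assay compound 2 gives 600 nM. The step of a 1.5-fold lower number from compound 2 to compound 3 (0.17 log units; within the scatter) is the only one measured between these two. Compound 1 `COc1cc(OCc2ccccc2OC)c2cc(-c3cn4nc(OC)sc4n3)oc2c1` is a separate case: in this assay compound 1 gives > 1000 nM, which is a limit of the assay and not a number (the limit of > 1000 nM in this assay, at which 1 of the 3 values shown sits). Among the two numbers shown, compound 3 and compound 2 lie within the scatter of each other, so neither is set apart.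

Compound 4 `COc1cc(OCc2cccc(C#N)c2)c2cc(-c3cn4nc(OC)sc4n3)oc2c1` differs from compound 3 in one place: cyano in place of phenylsulfanyl on an aromatic carbon. For the measured compounds named here, no measured step bears directly on this change; the step of a 1.5-fold lower number from compound 2 to compound 3 (0.17 log units; within the scatter) swaps one aryl-bearing group for another and does not tell what happens when the aryl is removed and cyano enters. The expectation for the step of a 2.9-fold higher number from compound 3 to compound 4 (0.47 log units; beyond the scatter) therefore rests on no measured guide and is set as a moderate loss. For compound 4 the estimate in this assay is 1200 nM, with a range from 400 nM to 4000 nM, and a real chance that only a limit is reported.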

Compound 4, half-maximal inhibitory concentration: 820 nM
Estimate against measurement, compound 4: 1.5-fold (0.17 log units) above; the measured number falls inside the stated range.
By their numbers in this assay, from the lowest: compounds 3, 2 and 4 (each within the scatter of the next). At a limit, above all of these: compound 1.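

In this assay, cyano in place of phenylsulfanyl gives a 2.0-fold higher number from compound 3 to compound 4 (0.30 log units; within the scatter), and cyano in place of phenoxymethyl gives a 1.4-fold higher number from compound 2 to compound 4 (0.14 log units; within the scatter). The earlier pair carried an aryl-bearing group at this place, on an aromatic carbon of a six-membered aromatic ring of carbon only, meta to a large group; compound 4 shows that a group with no ring can stand there and the number stays within the scatter of both. Compound 1 gives > 1000 nM, which is a limit of the assay and not a number. 3-cyanophenyl in place of 2-methoxyphenyl gives an at least 1.2-fold lower number from compound 1 to compound 4 (0.08 log units; that floor lies within the scatter). This is the only limit here: the limit of > 1000 nM in this assay, at which 1 of the 4 values shown sits.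

The compounds shown leave open whether an amine, a carboxylic acid or a longer alkyl chain at this place would also stay within the scatter of these three numbers. They also leave open whether any group here can set a compound apart from the others in this assay, as the three numbers shown lie within the scatter of one another.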